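The compounds below may be only part of what the source reports. "The series", "measured", "known", "first", "only" and "open" are said of these compounds alone.

Measured so far in a functional assay on COLO 205 cells (Homo sapiens) for cytotoxicity; on this read-out higher numbers stand for weaker inhibition and lower numbers for stronger inhibition:
compound 1 `COc1ccc(-n2nc(Nc3cc(C)[nH]n3)c3ccccc3c2=O)cc1` gives 3700 nM
compound 2 `COc1ccc(Cn2nc(Nc3cc(C)[nH]n3)c3ccccc3c2=O)cc1` gives 4200 nM
compound 3 `Cc1cc(Nc2nn(-c3ccc(F)cc3)c(=O)c3ccccc23)n[nH]1` gives 1600 nM

Compound 3 holds the lowest of the three values, and its gaps to the other two lie beyond the scatter. Compound 4 `Cc1cc(Nc2nn(C)c(=O)c3ccccc23)n[nH]1` carries methyl in place of 4-fluorophenyl on an aromatic nitrogen. Two measured steps change the group on that nitrogen. One (a 1.1-fold higher number from compound 1 to compound 2 (0.06 log units; within the scatter)) stayed within the scatter, and the other (a 2.6-fold lower number from compound 2 to compound 3 (0.42 log units; beyond the scatter)) was modest. A third (a 2.3-fold lower number from compound 1 to compound 3 (0.36 log units; beyond the scatter)) changes only the substituent on the aromatic ring and was also modest. Among the compounds with values here, no measured compound lacks an aromatic ring in this group, so the estimate is an extrapolation and carries wide uncertainty. With compound 3 already lowest, a modest rise in the number is expected in this assay. The expected change is a 3.1-fold higher number from compound 3 to compound 4 (0.49 log units; beyond the scatter) on this estimate. For compound 4 the estimated value is 5000 nM with an expected range from 1500 nM to 18000 nM in this read-out.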

Compound 4, half-maximal inhibitory concentration: > 30000 nM
Compound 4 ended at the assay's limit; the forecaster's own chance of this, stated with the estimate: 15%; at least 6.0-fold (0.77 log units) between middle value and limit.
By their numbers in this assay, from the lowest: compound 3; then compounds 1 and 2 (each within the scatter of the next). At a limit, above all of these: compound 4.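

In this assay the value of compound 4 is a limit of the assay and not a number: the limit of > 30000 nM in this assay, at which 1 of the 4 values shown sits.

Changes among the groups carrying an aromatic ring on this aromatic nitrogen shifted the number by little or modestly, whereas methyl brings a far larger change: an at least 18-fold higher number from compound 3 to compound 4 (1.27 log units; beyond the scatter), alongside an at least 8.1-fold higher number from compound 1 to compound 4 (0.90 log units; beyond the scatter) and an at least 7.1-fold higher number from compound 2 to compound 4 (0.85 log units; beyond the scatter). Among the compounds shown, all three with a six-membered aromatic ring of carbon only in this group give measurable numbers, and compound 4, with methyl, is the only one at the limit, so this position tolerates exchange among those ring-bearing groups but not their replacement by methyl.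

From the compounds shown here alone, what remains open is whether the aromatic ring itself is required or whether any larger group would do. A cyclohexyl group or a longer chain such as n-butyl on this nitrogen would separate the two.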